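The compounds below may be only part of what the source reports. "The series", "measured", "known", "first", "only" and "open" are said of these compounds alone.

In a physicochemical assay for acid dissociation, compound 1 `C=CC(CCC)OC[n+]1ccn(C)c1/C=N/O` gives 7.99 and compound 2 `C#CCC(CCC)OC[n+]1ccn(C)c1/C=N/O` gives 7.92, so compound 2 sits level with compound 1 within the scatter. Compound 3 `C#CCC(OC[n+]1ccn(C)c1/C=N/O)c1ccccc1` differs from compound 2 by phenyl in place of propyl on a saturated chain carbon bound to an oxygen on a saturated carbon and a saturated chain carbon, with phenyl in place of propyl on a saturated chain carbon bound to an oxygen on a saturated carbon and a saturated chain carbon. Going by the values given here, the only measured step, a number 0.07 log units lower from compound 1 to compound 2 (within the scatter), replaced a different group on that carbon and offers indirect guidance. Among the compounds with values here, no measured step exchanges propyl for phenyl. The expected change in this assay is a number 0.07 log units lower from compound 2 to compound 3 (within the scatter), with no shift beyond the scatter anticipated. For compound 3 the estimated value is 7.85, within a range of 7.6 to 8.1.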

Compound 3, acid dissociation constant: 7.99
For compound 3 the middle estimate is 0.14 log units below the measured one; low and high end bracket the measured number.
By their numbers in this assay, from the lowest: compounds 2, 1 and 3 (each within the scatter of the next).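

In this assay the step of a number 0.07 log units higher from compound 2 to compound 3 (within the scatter) comes with phenyl in place of propyl on a saturated chain carbon bound to an oxygen on a saturated carbon and a saturated chain carbon. This position therefore carries either a propyl chain or an aromatic phenyl ring with no shift beyond the scatter, whereas the earlier pair covered only vinyl and propargyl. No further data explain this result. Going by these compounds, whether an amine, a carboxylic acid or a longer chain at this carbon would also stay within the scatter remains open.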